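Ring-nitrogen methylation and maximal response at alpha4/beta2

The source may report more compounds than this note shows. Statements on the series, on what has been measured and on what is new or still open speak of the compounds shown alone.

Compound 1 `C1=C(c2cccnc2)C[C@@H]2CNC[C@H]1C2`: 32%
Compound 2 `CN1C[C@@H]2C=C(c3cccnc3)C[C@@H](C2)C1`: 18%
Compound 3 `CC(C)Oc1cncc(C2=CC3CNCC(C2)C3)c1`: 11%

In an in vitro functional assay on SH-EP1 cells for agonist activity at Neuronal acetylcholine receptor; alpha4/beta2 (Homo sapiens), read by voltage clamp (a higher number here means a larger maximal response, a lower number a smaller maximal response), compound 1 gives 32%. Compound 2 carries the change methyl in place of hydrogen on an amine nitrogen in a ring and gives 18% in this assay, so a number 14 percentage points lower from compound 1 to compound 2 (beyond the scatter). Compound 3 has a different core; the difference between the two cores is not broken down here. In this assay compound 3 gives 11%, the lowest of the three numbers, though its gap to compound 2 lies within the scatter.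

Compound 4 `CC(C)Oc1cncc(C2=CC3CC(C2)CN(C)C3)c1` is not yet measured. It differs from compound 3 by methyl in place of hydrogen on an amine nitrogen in a ring, the same change that separates compound 1 from compound 2. Because a number 14 percentage points lower from compound 1 to compound 2 (beyond the scatter), a further drop is expected, but the starting number of compound 3 is already small, so the expected step is a number 6 percentage points lower from compound 3 to compound 4 (within the scatter). Compound 4 is thus estimated at 5%, with a range from 0% to 14%.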

Compound 4, largest response reached (reported as percent of maximum), in percent of the reference or control that the assay uses: 10%
Beside the measured number, compound 4's estimate is 5 percentage points below it; low and high end bracket the measured number.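

In this assay, methyl in place of hydrogen on an amine nitrogen in a ring gives a number 1 percentage points lower from compound 3 to compound 4 (within the scatter). Set beside the earlier step on the other core, the two steps cannot be told apart: the same change on two cores in this assay, a number 14 percentage points lower (beyond the scatter) from compound 1 to compound 2 and a number 1 percentage points lower (within the scatter) from compound 3 to compound 4, 13 percentage points apart, within the scatter of two such steps. Among the compounds shown here, this shows that the two cores give no firm sign of responding differently to the change, but two pairs do not establish that it carries over with the same size, since only the step on the core of compound 1 lies beyond the scatter.

The compounds shown leave open what an ethyl group or a longer chain on that amine nitrogen would give in this assay. They also leave open whether a third core would behave like either of these two.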